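Moving the halogen across the triazole-bound phenyl ring

A few compounds are considered here, and "the series" means these few. Any claim that something is new, unique, unknown or untested is made for them only; others in the source may bear on it.

Compound 1 `N#CC1=C(N)Oc2c(c3nc4ccccc4nc3c3ccccc23)C12C(=O)N(Cc1cnnn1-c1ccccc1Cl)c1ccccc12` and compound 2 `N#CC1=C(N)Oc2c(c3nc4ccccc4nc3c3ccccc23)C12C(=O)N(Cc1cnnn1-c1cccc(Br)c1)c1ccccc12` share one core, while compound 3 `N#CC1=C(N)Oc2c(N)cc3nc4ccccc4nc3c2C12C(=O)N(Cc1cnnn1-c1ccccc1Cl)c1ccccc12` and compound 4 `N#CC1=C(N)Oc2c(N)cc3nc4ccccc4nc3c2C12C(=O)N(Cc1cnnn1-c1cccc(Br)c1)c1ccccc12` share a second; the difference between the two cores is not broken down here. In a functional assay on A549 cells (Homo sapiens) for antiproliferative activity, read by MTT assay, with a stated time of 48 h (on this read-out higher numbers stand for weaker inhibition and lower numbers for stronger inhibition), compound 1 gives 42600 nM. For compound 2 this assay reports only a limit, > 50000 nM. The change from compound 1 to compound 2 is 3-bromophenyl in place of 2-chlorophenyl on an aromatic nitrogen, and it made a step of an at least 1.1-fold higher number from compound 1 to compound 2 (0.06 log units; that floor lies within the scatter), with compound 2 sitting at the limit of > 50000 nM in this assay, at which 1 of the 3 values shown sits. Compound 3 gives 29800 nM in this assay, and its value and that of compound 1 lie within the scatter of each other. Compound 4 carries the same change on the second core, (3-bromophenyl in place of 2-chlorophenyl on an aromatic nitrogen), with the surroundings of the change reading the same for both pairs. Resting on the earlier step of an at least 1.1-fold higher number from compound 1 to compound 2 (0.06 log units; that floor lies within the scatter), the expected step here is a 1.5-fold higher number from compound 3 to compound 4 (0.18 log units; within the scatter). Compound 4 is therefore estimated at 45000 nM, with a likely range from 20000 nM to 120000 nM, and a fair chance that this assay reports only a limit for it.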

Compound 4, half-maximal inhibitory concentration: 18900 nM
Estimate against measurement, compound 4: 2.4-fold (0.38 log units) above; the whole stated range lies above it.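

On the second core, the change from 2-chlorophenyl to 3-bromophenyl gives a 1.6-fold lower number from compound 3 to compound 4 (0.20 log units; within the scatter). In this assay compound 2 is recorded only as a limit, > 50000 nM, and the step on the first core therefore has a floor but no measured size. The two cores thus show neither that this change carries over from one to the other nor that it acts differently on each: the same change on two cores in this assay, an at least 1.1-fold higher number (0.06 log units; that floor lies within the scatter) from compound 1 to compound 2 and a 1.6-fold lower number (0.20 log units; within the scatter) from compound 3 to compound 4; the limit leaves it open whether they differ

In this change the halogen and its place on the phenyl ring alter together, so the compounds shown leave open which of the two, if either, matters in this assay. Also open, on these data alone, is how a plain phenyl group or a methoxyphenyl group on the triazole nitrogen would read on either core.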